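Swapping the aryl group on the hydrazone arm

The compounds below may be only part of what the source reports. "The series", "measured", "known", "first", "only" and "open" are said of these compounds alone.

Three compounds of one series have been measured in a functional assay on HCT-116 cells (Homo sapiens) for inhibition, read by MTT assay, with a stated time of 48 h; a lower number here means a stronger inhibitor, a higher number a weaker inhibitor:

Compound 1, `Fc1ccc(CSc2nnc(-c3ccncc3)n2-c2ccccc2)c(F)c1`, gives 11400 nM.
Compound 2, `O=[N+]([O-])c1cccc(CSc2nnc(-c3ccncc3)n2-c2ccccc2)c1`, gives 19800 nM.
Compound 3, `O=C(CSc1nnc(-c2ccncc2)n1-c1ccccc1)N/N=C/c1ccc([N+](=O)[O-])cc1`, gives 10200 nM.

Compound 3 carries the smallest number of the three, but its distance to compound 1 and to compound 2 is within the scatter, so the three compounds cannot be told apart in this assay. Among the compounds with values here, the one step that links two measured compounds, a 1.7-fold higher number from compound 1 to compound 2 (0.24 log units; within the scatter), exchanges one aryl group for another on a saturated chain carbon bound to a sulfur and stays within the scatter.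

Compound 4, `O=C(CSc1nnc(-c2ccncc2)n1-c1ccccc1)N/N=C/c1ccccc1F`, differs from compound 3 by 2-fluorophenyl in place of 4-nitrophenyl on a carbon with a double bond to nitrogen. Within the data shown here, this is again an exchange of one aryl group for another, here on a carbon with a double bond to nitrogen, and the only comparable exchange, from compound 1 to compound 2, moved the number by less than the scatter. No step beyond the scatter is therefore expected in this assay for compound 4. Compound 4 is expected to give about 10000 nM, between 4000 nM and 25000 nM, which would mean an estimated step of a 1.0-fold lower number from compound 3 to compound 4 (0.01 log units; within the scatter).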

Compound 4, half-maximal inhibitory concentration: 18000 nM
The estimate for compound 4 lay 1.8-fold (0.26 log units) below the measured number, within the range that was stated.
By their numbers in this assay, from the lowest: compounds 3, 1, 4 and 2 (each within the scatter of the next).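

At the carbon with a double bond to nitrogen, replacing 4-nitrophenyl with 2-fluorophenyl in this assay gives a 1.8-fold higher number from compound 3 to compound 4 (0.25 log units; within the scatter), so this exchange, which also takes away the hydrogen-bond acceptors counted for 4-nitrophenyl, does not separate the two compounds. The earlier compounds shown here had offered a reading of an aryl exchange only on a saturated chain carbon bound to a sulfur, and this step extends that result to a second place, where an aryl exchange again stays within the scatter. No measurement is available that bears on why the number holds at this position.

The step changes both the substituent and where it stands on the ring, so the compounds shown cannot separate these two changes, and a single pair at this position says little about the range of groups that would leave the number in place. On these data alone, whether the result would hold for a plain phenyl, for a phenyl carrying an amine or a carboxylic acid, or for a longer chain in place of the aryl group remains open.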